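The source may report more compounds than this note shows. Statements on the series, on what has been measured and on what is new or still open speak of the compounds shown alone.

Measured in an ADME assay on MT4 cells (Homo sapiens) for cytotoxicity, read by MTT assay, with a stated time of 96 h; on this read-out higher numbers stand for lower toxicity in this test and lower numbers for higher toxicity in this test:
compound 1 `COc1ccc(-c2nc3cc(Cl)c(Cl)cc3[nH]2)cc1` gives 1000 nM.
compound 3 `COc1ccc(-c2nc3cc(Cl)c(Cl)cc3[nH]2)c([N+](=O)[O-])c1` gives 2000 nM.
compound 2 `CCC(=O)Nc1ccc(-c2nc3cc(C(F)(F)F)ccc3[nH]2)cc1` gives >= 100000 nM, which is a limit of the assay and not a number.

Compound 1 holds the lowest of the two numbers; compound 3 sits nearest, with a 2.0-fold higher number from compound 1 to compound 3 (0.30 log units; within the scatter). Among the compounds with values here, the one further value recorded is a limit, as noted in the limit of >= 100000 nM in this assay, at which 1 of the 3 values shown sits.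

Compound 4 `CC(=O)Nc1ccc(-c2nc3cc(Cl)c(Cl)cc3[nH]2)cc1` differs from compound 1 as follows: acetamido in place of methoxy on an aromatic carbon. Within the data shown here, no measured step covers this change. Among the measured compounds shown here, the single measured step, a 2.0-fold higher number from compound 1 to compound 3 (0.30 log units; within the scatter), concerns a nitro group at another place on the same ring and says nothing about an acetamido group. Compound 2 carries a propanamido group on the six-membered aromatic ring of carbon only, though on a different core, and its value is a limit; it offers only a hint that an amide there may go with a higher number in this assay.

Expectation for compound 4 in this assay is therefore a higher number than compound 1, a 10-fold higher number from compound 1 to compound 4 (1.00 log units; beyond the scatter), with wide uncertainty. The hint rests on compound 2 alone and on a limit. Estimated value for compound 4: 10000 nM, range 1500 nM to 100000 nM.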

Compound 4, half-maximal cytotoxic concentration: > 100000 nM
Compound 4 gave a limit, no number; the forecaster's own chance of this, stated with the estimate: 30%; middle value at least 10-fold (1.00 log units) away from the limit.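

In this assay, acetamido in place of methoxy on an aromatic carbon, para to a large group, gives an at least 100-fold higher number from compound 1 to compound 4 (2.00 log units; beyond the scatter), the only measured step shown at this position. Within the data shown here, the one earlier step, a 2.0-fold higher number from compound 1 to compound 3 (0.30 log units; within the scatter), concerns nitro in place of hydrogen at another place on the ring, so it could not show that a change at the methoxy position can move the read-out beyond the scatter. The value of compound 4 is a limit of the assay and not a number: the limit of > 100000 nM in this assay, at which 1 of the 4 values shown sits.

The compounds shown give no cause for this step and leave its full size open, since only its lower bound can be read from a limit. On these data alone, it also remains open which part of the acetamido group goes with the change, the amide hydrogen, the carbonyl or the added heavy atoms: a free amine or a carboxylic acid at this position, or a longer chain on the amide, would help to separate these on the core of compound 1.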